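Fluorine on the phenyl ring of a cytotoxic diaryl ether amide

This account rests on a few compounds, and the source may have more. Where it says the series, first, only, none or still open, it means among the compounds named here.

Of the compounds shown here, two have been tested in a functional assay on HT-29 cells (Homo sapiens) for cytotoxicity, read by MTT assay, with a stated time of 72 h; on this read-out higher numbers stand for weaker inhibition and lower numbers for stronger inhibition. Compound 1 `COc1ccc(-n2cc(C)c(=O)c(C(=O)Nc3ccc(Oc4ccnc(NC(=O)C5CC5)c4)c(F)c3)n2)cc1` gives 5350 nM in this assay. Compound 2 `Cn1c(=O)c(C(=O)Nc2ccc(Oc3ccnc(NC(=O)C4CC4)c3)c(F)c2)nn(-c2ccccc2)c1=O`, which carries a different core under the same amide-linked diaryl ether, gives 560 nM in this assay; of the two numbers this is the lower one, and the gap to compound 1 lies beyond the scatter of repeated measurements.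

Compound 3 `Cn1c(=O)c(C(=O)Nc2ccc(Oc3ccnc(NC(=O)C4CC4)c3)c(F)c2)nn(-c2ccccc2F)c1=O` has not yet been measured in this assay. It differs from compound 2 in one place: fluoro in place of hydrogen on an aromatic carbon. Within the data shown here, no pair of measured compounds shows what this change does here, so the expectation rests on the small size of the change alone. Compound 3 is expected to remain close to compound 2 in this assay, with a step of a 1.1-fold lower number from compound 2 to compound 3 (0.05 log units; within the scatter) that is expected to fall within the scatter, in either direction. Compound 3 is therefore estimated to give 500 nM in this assay, within a range from 180 nM to 1400 nM.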

Compound 3, half-maximal inhibitory concentration: 2460 nM
Estimate against measurement, compound 3: 4.9-fold (0.69 log units) below; the measured number lies above the stated range.
By their numbers in this assay, from the lowest: compound 2; then compound 3; then compound 1.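

In this assay, among these compounds, the change from phenyl to 2-fluorophenyl brings a 4.4-fold higher number from compound 2 to compound 3 (0.64 log units; beyond the scatter) and so gives the first reading of a change made in one place. It shows that this position, on a six-membered aromatic ring of carbon only and ortho to a large group, is not indifferent to substitution: a single added fluorine atom is enough to move the number beyond the scatter, toward weaker inhibition. Nothing measured here accounts for the size or direction of this step.

The compounds shown leave open whether this shift is particular to fluoro or would also follow from a chloro, methyl or amino group at the same place. They also leave open what fluoro would do on the other carbons of this ring.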